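A few compounds are considered here, and "the series" means these few. Any claim that something is new, unique, unknown or untested is made for them only; others in the source may bear on it.

Compound 3 `O=C1/C(=C/c2ccccc2F)CN(C(=S)SCc2cn(Cc3cccc(Cl)c3)nn2)C/C1=C\c1ccccc1F` and compound 1 `O=C1/C(=C/c2ccccc2F)CN(C(=S)SCc2cn(Cc3ccccc3Cl)nn2)C/C1=C\c1ccccc1F` are built on one shared core, while compound 2 `COc1ccc(/C=C2\CN(C(=S)SCc3cn(Cc4cccc(Cl)c4)nn3)C/C(=C\c3ccc(OC)cc3)C2=O)cc1` and the not yet measured compound 4 `COc1ccc(/C=C2\CN(C(=S)SCc3cn(Cc4ccccc4Cl)nn3)C/C(=C\c3ccc(OC)cc3)C2=O)cc1` are built on another; how the two cores differ is not broken down here. In a functional assay on MDA-MB-231 cells (Homo sapiens) for cytotoxicity, read by MTT assay, with a stated time of 24 h (on this read-out lower numbers stand for stronger inhibition and higher numbers for weaker inhibition), compound 3 reaches only a limit of the assay, > 100000 nM, and gives no number. Compound 1 in this assay gives 100000 nM. The structural change from compound 3 to compound 1 is 2-chlorophenyl in place of 3-chlorophenyl on a saturated chain carbon bound to an aromatic nitrogen, and the step of a number no higher from compound 3 to compound 1 (the limit leaves the size open) cannot be sized because compound 3 sits at the limit of > 100000 nM in this assay, at which 1 of the 3 values shown sits. In this assay compound 2 gives 32000 nM, the lower of the two numbers that were obtained, and the gap between compound 2 and compound 1 lies beyond the usual scatter.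

Compound 4 is related to compound 2 by the same change, (2-chlorophenyl in place of 3-chlorophenyl on a saturated chain carbon bound to an aromatic nitrogen), made on the other core. Since the earlier step from compound 3 to compound 1 showed a number no higher after this change but left its size open, the expected step from compound 2 to compound 4 is a 1.1-fold lower number from compound 2 to compound 4 (0.06 log units; within the scatter), close to no change. On that basis compound 4 is estimated to give 28000 nM in this assay, with an expected range from 10000 nM to 80000 nM.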

Compound 4, half-maximal inhibitory concentration: > 100000 nM
Compound 4 ended at the assay's limit; the forecaster's own chance of this, stated with the estimate: 10%; middle value at least 3.5-fold (0.55 log units) from the limit.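

In this assay, putting 2-chlorophenyl in place of 3-chlorophenyl on the core of compound 2 gives an at least 3.1-fold higher number from compound 2 to compound 4 (0.49 log units; beyond the scatter), so this single change cannot be assumed to act the same way on both cores: the same change on two cores in this assay, a number no higher (the limit leaves the size open) from compound 3 to compound 1 and an at least 3.1-fold higher number (0.49 log units; beyond the scatter) from compound 2 to compound 4, at least 3.1-fold (0.49 log units) apart, beyond the scatter of two such steps

Compound 4 gives > 100000 nM, which is a limit of the assay and not a number.

This shows that the chlorine's place on the ring matters on the core of compound 2, but it does not show the true size of that step, and the steps that involve a limit cannot be read exactly, so the real gap between the two cores stays unknown: the limit of > 100000 nM in this assay, at which 2 of the 4 values shown sit.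

The result rests on a single pair of compounds on each of two cores, so it gives no general rule for the series, and it does not explain why the cores differ. The compounds shown also leave open what would happen on either core if the chlorobenzyl group gave way to a plain benzyl group, a bromobenzyl group or a longer chain such as phenylethyl, and whether the same change would behave in either way on a third core.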